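The source may hold more compounds than are shown below. What is called first, only, known or untested is meant among the compounds shown, and "the series" means these compounds.

Measured so far:
- compound 1, `COc1cc(-c2cc(/C=C/C(=O)c3ccc(Cl)c(Cl)c3)[nH]n2)cc(OC)c1OC`: 91%
- compound 2, `COc1ccc(-c2cc(/C=C/C(=O)c3ccc(N)cc3)[nH]n2)cc1`: 95%

In a functional assay on CAKI-1 cells (Homo sapiens) for cytotoxicity, read by sulforhodamine B assay, with a stated time of 48 h, tested at 0.01 uM (on this read-out higher numbers stand for a weaker effect at the one concentration tested and lower numbers for a stronger effect), compound 1 gives 91%, the lowest of the two numbers shown. Its nearest neighbour is compound 2, which in this assay gives 95%; the gap between the two lies within the usual scatter of the read-out, so the two compounds cannot be told apart on these numbers, and both stand at the weak end of the scale at the one concentration tested. For the measured compounds named here, compound 1 and compound 2 differ in more than one place, and no single-change step between measured compounds is available.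

Compound 3, `COc1cc(-c2cc(/C=C/C(=O)c3ccc(F)c(F)c3)[nH]n2)cc(OC)c1OC`, is not yet measured. It differs from compound 1 in one place: 3,4-difluorophenyl in place of 3,4-dichlorophenyl on a carbonyl carbon. Going by the values given here, the series holds no measured pair that isolates this kind of exchange, so nothing in the numbers points to a shift in either direction. With compound 1 at 91% and compound 2 at 95% both sitting high on the scale, the expectation for compound 3 in this assay is a step of no size beyond the scatter, in no particular direction. The estimated step of a number 1 percentage points higher from compound 1 to compound 3 (within the scatter) is expected to remain within the scatter. For compound 3 the estimate in this assay is 92%, with a range from 80% to 100%.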

Compound 3, a percentage reported as activity, at one concentration (the size of the read-out at that concentration, not a potency): 95%
Compound 3: the middle estimate sits 3 percentage points below what was measured, and the stated range covers the measured number.
By their numbers in this assay, from the lowest: compounds 1, 2 and 3 (each within the scatter of the next).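

In this assay, for the compounds shown here, the exchange of 3,4-dichlorophenyl for 3,4-difluorophenyl on the carbonyl carbon provides the only single-change step so far: a number 4 percentage points higher from compound 1 to compound 3 (within the scatter). This step shows that, with the rest of compound 1 held constant, replacing the two chlorine atoms with two fluorine atoms at this place produces no separable change at the one concentration tested, which the earlier comparison of compound 1 and compound 2, differing in more than one place, could not show. No supporting data bear on why the read-out behaves this way at this position.

The compounds shown leave open whether this place is insensitive to substitution generally or only to this exchange of one halogen pair for another, since an unsubstituted phenyl, a 3,4-dimethoxyphenyl or a phenyl carrying a carboxylic acid could still separate from compound 1. Also open, on these data alone, is whether compound 1 and compound 3 would remain indistinguishable at a higher concentration, where the read-out might move away from the weak end of the scale.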